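Methoxy on the Benzyl Group: Two Cores Compared

The source may report more compounds than this note shows. Statements on the series, on what has been measured and on what is new or still open speak of the compounds shown alone.

Of the compounds shown here, three have been measured in a functional assay on HepG2 cells (Homo sapiens) for cytotoxicity, read by MTT assay, with a stated time of 72 h; a higher number here means a weaker inhibitor, a lower number a stronger inhibitor. Compound 3 `CC(C)(Oc1ccc2c(=O)cc(-c3ccccc3)oc2c1)C(=O)NC1CCN(Cc2ccccc2)CC1` gives 14000 nM. Compound 2 `COc1ccc(CN2CCC(NC(=O)C(C)(C)Oc3ccc4c(=O)cc(-c5ccccc5)oc4c3)CC2)cc1` carries a methoxy group where compound 3 carries hydrogen, and compound 2 gives 8700 nM in this assay. The step of a 1.6-fold lower number from compound 3 to compound 2 (0.21 log units; within the scatter) corresponds to the change (methoxy in place of hydrogen on an aromatic carbon). Compound 1 `CC(C)(Oc1ccc(-c2cc(=O)c3ccccc3o2)cc1)C(=O)NC1CCN(Cc2ccccc2)CC1` is built from the same atoms as compound 3, joined differently; the difference between the two cores is not broken down here. For compound 1 this assay reports only a limit and no number, > 20000 nM, as noted in the limit of > 20000 nM in this assay, at which 1 of the 3 values shown sits.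

Compound 4 `COc1ccc(CN2CCC(NC(=O)C(C)(C)Oc3ccc(-c4cc(=O)c5ccccc5o4)cc3)CC2)cc1` has not yet been measured in this assay. It differs from compound 1 by methoxy in place of hydrogen on an aromatic carbon, the same change that separates compound 3 from compound 2. Since compound 1 sits at the limit of this assay, and since the same change gave a 1.6-fold lower number from compound 3 to compound 2 (0.21 log units; within the scatter), compound 4 is expected to remain close to that limit. Compound 4 is therefore estimated at about 20000 nM, most likely between 10000 nM and 40000 nM, an expected step of a number no higher from compound 1 to compound 4 (the limit leaves the size open).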

Compound 4, half-maximal inhibitory concentration: 2800 nM
Compound 4: middle estimate off by 7.1-fold (0.85 log units), on the high side; measured number below the stated range.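

In this assay, methoxy in place of hydrogen, which turns benzyl into 4-methoxybenzyl, gives an at least 7.1-fold lower number from compound 1 to compound 4 (0.85 log units; beyond the scatter). The size of the step therefore did not carry over from one core to the other: the same change on two cores in this assay, a 1.6-fold lower number (0.21 log units; within the scatter) from compound 3 to compound 2 and an at least 7.1-fold lower number (0.85 log units; beyond the scatter) from compound 1 to compound 4, at least 4.4-fold (0.64 log units) apart, beyond the scatter of two such steps

Two cores show only that the step can differ with the core, not why it differs or how large it is on the core of compound 1, whose value is a limit and not a number: the limit of > 20000 nM in this assay, at which 1 of the 4 values shown sits.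

The compounds shown leave open whether another group in the same place, such as hydroxyl, ethoxy or chlorine, would also give steps that differ between the two cores. They also leave open whether the gap between the two cores would remain if a longer chain replaced the linking chain that joins each core to the amide.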